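A few compounds are considered here, and "the series" means these few. Any claim that something is new, unique, unknown or untested is made for them only; others in the source may bear on it.

Of the compounds shown here, three have been tested in an ADME assay on RAW264.7 cells (Mus musculus) for cytotoxicity, read by MTT assay, with a stated time of 48 h; a lower number here means a stronger inhibitor, a higher number a weaker inhibitor: compound 1 `O=C(CCCCC1CCSS1)OCCCOC(=O)c1cccnc1`, compound 2 `COc1ccc(NC(=S)OCCNC(=O)c2cccnc2)cc1` and compound 3 `NC(=S)c1ccc(OC(=O)c2cccnc2)cc1`. Compound 1 gives > 800000 nM, which is a limit of the assay and not a number. Compound 2 gives > 800000 nM, which is also a limit. Compound 3 gives > 800000 nM, again only a limit, so it cannot be placed in any order against the other two. What the series shows so far is the limit of > 800000 nM in this assay, at which 3 of the 3 values shown sit.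

Compound 4 `O=C(Oc1ccc(-c2cc(=S)ss2)cc1)c1cccnc1` differs from compound 3 in one place: a group of 6 heavy atoms (3 carbon, 3 sulfur; one five-membered aromatic ring with 2 hetero atoms) in place of a group of 3 heavy atoms (1 carbon, 1 nitrogen, 1 sulfur; no ring), on an aromatic carbon. A group with one five-membered aromatic ring with 2 hetero atoms replaces a group with no ring, on an aromatic carbon.

For the measured compounds named here, no measured step gives a size for this change. In this assay a moderate move toward a lower number is expected, although the result could stay at the same limit. The estimated change is an at least 2.6-fold lower number from compound 3 to compound 4 (0.42 log units; beyond the scatter). For compound 4 the expected value is 300000 nM, with an estimated range of 60000 nM to 800000 nM.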

Compound 4, half-maximal inhibitory concentration: > 800000 nM
Compound 4: no number, only a limit; the forecaster's own chance of this, stated with the estimate: 45%; middle value at least 2.6-fold (0.42 log units) from the limit.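

In this assay compound 4 gives > 800000 nM, which is a limit and not a number. For the compounds shown here, compound 3 also stands at a limit, so no step between compound 3 and compound 4 can be read. The compounds shown leave open how far any of them lies beyond this limit: the limit of > 800000 nM in this assay, at which 4 of the 4 values shown sit.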